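Amide Side Chain Swap at the Assay Limit

This account rests on a few compounds, and the source may have more. Where it says the series, first, only, none or still open, it means among the compounds named here.

In a functional assay on BXPC-3 cells (Homo sapiens) for antiproliferative activity, read by MTT assay, with a stated time of 24 h (on this read-out lower numbers stand for stronger inhibition and higher numbers for weaker inhibition), compound 1 (`CCn1c(C(=O)N[C@@H](CC(=O)OC)C(=O)OC)ccc1C(CC)(CC)c1ccc(OCS(=O)(=O)c2ccccc2)c(C)c1`) gives > 50000 nM as a limit of the assay. Compound 2 (`CCn1c(C(=O)N[C@H](CO)CCCO)ccc1C(CC)(CC)c1ccc(OCS(=O)(=O)c2ccccc2)c(C)c1`) gives > 50000 nM as a limit too, so it has no exact number. Compound 3 (`CCn1c(C(=O)N[C@@H](C(=O)O)C(C)C)ccc1C(CC)(CC)c1ccc(OCS(=O)(=O)c2ccccc2)c(C)c1`) carries 1-carboxy-2-methylpropyl on the amide-type nitrogen, a change counted as a group of 7 heavy atoms (5 carbon, 2 oxygen; no ring) in place of a group of 7 heavy atoms (5 carbon, 2 oxygen; no ring), on an amide-type nitrogen in full. For the measured compounds named here, the only measured step bearing on it is a step that the two limits leave unreadable from compound 1 to compound 2 and it gives no size, while the limit of > 50000 nM in this assay, at which 2 of the 2 values shown sit, holds for both compounds. The expected step is a number no higher from compound 2 to compound 3 (the limit leaves the size open) with no direction readable. Compound 3 is estimated at 50000 nM with an expected range from 20000 nM to 100000 nM as its likely span.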

Compound 3, half-maximal inhibitory concentration: 13900 nM
Estimate against measurement, compound 3: 3.6-fold (0.56 log units) above; the whole stated range lies above it.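

In this assay, the amide-type nitrogen carries in compound 3 a side chain that gives a measured number, which neither earlier compound provided. The step to 1-carboxy-2-methylpropyl is an at least 3.5-fold lower number from compound 2 to compound 3 (0.55 log units; beyond the scatter), and the same group in place of 1,2-bis(methoxycarbonyl)ethyl gives an at least 3.5-fold lower number from compound 1 to compound 3 (0.55 log units; beyond the scatter). Both steps have an open size, with the two starting compounds standing only as limits: the limit of > 50000 nM in this assay, at which 2 of the 3 values shown sit.

On these data alone, whether an amine or a longer chain at this place would lower the number further stays open. As far as these compounds go, the true size of both steps also remains unknown.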